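Vero cytotoxicity across aryl variants of a hydrazone series

A few compounds are considered here, and "the series" means these few. Any claim that something is new, unique, unknown or untested is made for them only; others in the source may bear on it.

Measured so far:
- compound 1, `N/C(=N/NC(CC(=O)c1ccc(-n2ccnc2)cc1)c1ccc(F)cc1)c1ccccn1`: 78800 nM
- compound 2, `N/C(=N/NC(CC(=O)c1ccc(-n2ccnc2)cc1)c1cccc([N+](=O)[O-])c1)c1ccccn1`: 28700 nM
- compound 3, `N/C(=N/NC(CC(=O)c1ccc(-n2ccnc2)cc1)c1ccc(Cl)cc1)c1ccccn1`: 78800 nM

All three share one core and differ only in the aryl group on the saturated chain carbon bound to an amine nitrogen and a saturated chain carbon. In an ADME assay on Vero cells (Chlorocebus sabaeus) for cytotoxicity, read by MTT assay, with a stated time of 72 h (a lower number here means that less compound is tolerated, a higher number that more compound is tolerated), compound 3 stands level with compound 1 at the digits shown, the two together giving the highest numbers of the three; the step of a 2.7-fold higher number from compound 2 to compound 3 (0.44 log units; beyond the scatter) is the only one that separates compound 3 from another member beyond the scatter, while no change at the digits printed from compound 1 to compound 3 (within the scatter) shows that swapping one halogen for another on the aromatic carbon left the read-out where it was.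

The next compound is compound 4, `N/C(=N/NC(CC(=O)c1ccc(-n2ccnc2)cc1)c1ccccc1F)c1ccccn1`, with the change (2-fluorophenyl in place of 4-chlorophenyl on a saturated chain carbon bound to an amine nitrogen and a saturated chain carbon). Going by the values given here, no measured step moves a halogen from one ring carbon to another; the one halogen-for-halogen step, no change at the digits printed from compound 1 to compound 3 (within the scatter), lay within the scatter, and the only steps beyond it, a 2.7-fold lower number from compound 1 to compound 2 (0.44 log units; beyond the scatter) and a 2.7-fold higher number from compound 2 to compound 3 (0.44 log units; beyond the scatter), involved the nitro group, which is absent here. The step from compound 3 to compound 4 in this assay is therefore expected to stay within the scatter, a 1.1-fold lower number from compound 3 to compound 4 (0.02 log units; within the scatter). Compound 4 is estimated at 75000 nM, with a range of 30000 nM to 160000 nM.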

Compound 4, half-maximal cytotoxic concentration: 62100 nM
Compound 4: the middle estimate sits 1.2-fold (0.08 log units) above what was measured, and the stated range covers the measured number.
By their numbers in this assay, from the lowest: compound 2; then compounds 4, 1 and 3 (each within the scatter of the next).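

In this assay, the same halogen on a different ring carbon, 2-fluorophenyl in place of 4-fluorophenyl, gives a 1.3-fold lower number from compound 1 to compound 4 (0.10 log units; within the scatter) and 2-fluorophenyl in place of 4-chlorophenyl gives a 1.3-fold lower number from compound 3 to compound 4 (0.10 log units; within the scatter) so among these compounds neither change moves the read-out past the scatter. Against the nitro compound the new member shows a 2.2-fold higher number from compound 2 to compound 4 (0.34 log units; beyond the scatter) and compound 2 therefore stands apart, beyond the scatter, from all three halogen-bearing compounds. No measurement available here bears on the reason for these numbers.

On these data alone, whether the lower number of compound 2 goes with the nitro group itself or with its place on the ring stays open, and a 3-fluorophenyl or 4-nitrophenyl group would bear on that. Also open, as far as these compounds go, is how this position responds to a group other than a halogen or nitro on the phenyl, such as an amine or a carboxylic acid.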